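This account rests on a few compounds, and the source may have more. Where it says the series, first, only, none or still open, it means among the compounds named here.

Measured compounds:
- compound 1, `COc1ccc(Cl)cc1N(CC(=O)N1CCc2ccccc21)S(=O)(=O)c1ccccc1`, which in a functional assay on SH-SY5Y cells (Homo sapiens), read by MTT assay, with a stated time of 24 h (on this read-out higher numbers stand for an effect only at larger amounts of compound and lower numbers for an effect already at smaller amounts), gives > 20000 nM, a limit of the assay rather than a number.
- compound 2, `CCCNC(=O)CN(c1cc(Cl)ccc1OC)S(=O)(=O)c1ccccc1`, which in this assay gives > 20000 nM, again a limit.
- compound 3, `CCN(CC)C(=O)CN(c1cc(Cl)ccc1OC)S(=O)(=O)c1ccccc1`, which in this assay gives > 20000 nM, also a limit.

Compound 3 therefore stands only at a limit, and so do the other two measured compounds; this is the limit of > 20000 nM in this assay, at which 3 of the 3 values shown sit. Among the compounds with values here, none of the measured steps can be read: a step that the two limits leave unreadable from compound 1 to compound 2, a step that the two limits leave unreadable from compound 1 to compound 3 and a step that the two limits leave unreadable from compound 2 to compound 3 all remain of unknown size.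

Compound 4, `COc1ccc(CNC(=O)CN(c2cc(Cl)ccc2OC)S(=O)(=O)c2ccccc2)cc1`, differs from compound 3 in one place: (4-methoxybenzyl)amino in place of diethylamino on a carbonyl carbon. Within the data shown here, no measured step shows what such a change does in this assay, since every comparison among compounds 1, 2 and 3 is hidden by the limit. Among the measured compounds shown here, the only guide is that three changes of the group on this carbonyl carbon left every compound at the limit, so for compound 4 the expected step of a number no higher from compound 3 to compound 4 (the limit leaves the size open) is no readable change. Compound 4 is therefore estimated at 20000 nM, within 8000 nM to 60000 nM, most likely again reported as a limit.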

Compound 4, half-maximal effective concentration: > 20000 nM
Compound 4 ended at the assay's limit; the forecaster's own chance of this, stated with the estimate: 85%; the middle value lies on the limit itself.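

The steps from compound 1, compound 2 and compound 3 to compound 4 cannot be read, because all four compounds give a limit rather than a number: the limit of > 20000 nM in this assay, at which 4 of the 4 values shown sit.

The compounds shown leave open how far apart these four really lie in this assay, and whether any change to the shared core would give a measurable value.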